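Chain terminus variation on the shared core: amine to acid

The source may report more compounds than this note shows. Statements on the series, on what has been measured and on what is new or still open speak of the compounds shown alone.

Compound 3 `Cn1ncc(Cl)c1-c1cc(C(=O)N[C@@H]2CN[C@H](CCN3CCCCC3)C[C@H]2c2ccc(Cl)c(Cl)c2)oc1Cl` gives 1780 nM in a functional assay on LNCaP cells (Homo sapiens) for antiproliferative activity; a lower number here means a stronger inhibitor, a higher number a weaker inhibitor. Among the three measured compounds it has the highest number: compound 1 `Cn1ncc(Cl)c1-c1cc(C(=O)N[C@@H]2CN[C@H](CCN3CCC(O)CC3)C[C@H]2c2ccc(Cl)c(Cl)c2)oc1Cl` gives 1140 nM, a gap that stays within the scatter, and compound 2 `Cn1ncc(Cl)c1-c1cc(C(=O)N[C@@H]2CN[C@H](CCCO)C[C@H]2c2ccc(Cl)c(Cl)c2)oc1Cl` gives 210 nM, a gap beyond it. The step of an 8.5-fold higher number from compound 2 to compound 3 (0.93 log units; beyond the scatter) and the step of a 5.4-fold lower number from compound 1 to compound 2 (0.73 log units; beyond the scatter) both show that replacing the cyclic amine at the chain end with a hydroxyl-bearing chain lowers the number by a modest margin, while a 1.6-fold higher number from compound 1 to compound 3 (0.19 log units; within the scatter) shows a change within the scatter.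

Compound 4 `Cn1ncc(Cl)c1-c1cc(C(=O)N[C@@H]2CN[C@H](CC(=O)O)C[C@H]2c2ccc(Cl)c(Cl)c2)oc1Cl` has not been measured in this assay. It differs from compound 3 as follows: carboxy in place of (piperidin-1-yl)methyl on a saturated chain carbon bound to a saturated ring carbon. Going by the values given here, the two bearing steps both trace removal of the cyclic amine, and both point to a lower number; the carboxy group has no measured counterpart in the set, so the size is uncertain. A step of a 2.5-fold lower number from compound 3 to compound 4 (0.41 log units; beyond the scatter) is expected. For compound 4 the estimate is 700 nM, with a range from 150 nM to 3500 nM.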

Compound 4, half-maximal inhibitory concentration: 640 nM
Beside the measured number, compound 4's estimate is 1.1-fold (0.04 log units) above it, and the stated range covers the measured number.
By their numbers in this assay, from the lowest: compound 2; then compounds 4, 1 and 3 (each within the scatter of the next, the first and the last beyond it).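

In this assay, carboxy on the saturated chain carbon bound to a saturated ring carbon shows that losing the cyclic amine does not by itself reproduce the number of compound 2, with a 3.0-fold higher number from compound 2 to compound 4 (0.48 log units; beyond the scatter). Set against the two cyclic amines, carboxy gives a 2.8-fold lower number from compound 3 to compound 4 (0.44 log units; beyond the scatter) and a 1.8-fold lower number from compound 1 to compound 4 (0.25 log units; within the scatter), and only the first of these steps lies beyond the scatter. No measurement is available that accounts for the gap between the carboxy and 2-hydroxyethyl ends.

From the compounds shown here alone, what stays open is whether the end group or the chain length separates compound 2 from compound 4. A carboxyethyl group, with the acid on a longer chain, and a hydroxymethyl group, with the alcohol on a shorter one, would test the two apart.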